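Bromo to hydroxy: notes on compound 4

The compounds below may be only part of what the source reports. "The series", "measured", "known", "first", "only" and "open" are said of these compounds alone.

In a functional assay on MDA-MB-468 cells (Homo sapiens) for inhibition, read by colorimetric assay, with a stated time of 3 days (on this read-out lower numbers stand for stronger inhibition and higher numbers for weaker inhibition), compound 2 (`O=C(CCCCCCNC(=O)C(O)(O)C(F)(F)F)Nc1ncc(-c2ccc(Br)cc2)s1`) gives 760 nM and compound 1 (`COc1ccc(-c2cnc(NC(=O)CCCCCCNC(=O)C(O)(O)C(F)(F)F)s2)cc1`) gives 1160 nM. These two lie within the scatter of each other, at the low end of the three numbers in hand. Compound 3 (`COc1ccc2sc(NC(=O)CCCCCCNC(=O)C(O)(O)C(F)(F)F)nc2c1`), with another core, gives 3650 nM, a number beyond the scatter from that of compound 2.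

The next compound is compound 4 (`O=C(CCCCCCNC(=O)C(O)(O)C(F)(F)F)Nc1ncc(-c2ccc(O)cc2)s1`), which changes compound 2 at one place: hydroxy in place of bromo on an aromatic carbon. This puts hydroxy in place of bromo on an aromatic carbon. Among the measured compounds shown here, only one measured step bears on that place, a 1.5-fold lower number from compound 1 to compound 2 (0.18 log units; within the scatter), with bromo in place of methoxy. For the measured compounds named here, no measured compound carries the hydroxy, so this single small step is a thin guide. No step beyond the scatter is expected in this assay, with a slight lean towards a higher number. The expected change is a 1.3-fold higher number from compound 2 to compound 4 (0.12 log units; within the scatter). For compound 4 the estimated value is 1000 nM, with an expected range of 350 nM to 2800 nM.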

Compound 4, half-maximal inhibitory concentration: 1100 nM
Estimate against measurement, compound 4: 1.1-fold (0.04 log units) below, within the range that was stated.
By their numbers in this assay, from the lowest: compounds 2, 4 and 1 (each within the scatter of the next); then compound 3.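

On the shared core, going from 4-bromophenyl to 4-hydroxyphenyl gives a 1.4-fold higher number from compound 2 to compound 4 (0.16 log units; within the scatter) in this assay and so stays within the scatter, even though hydroxy brings a hydrogen-bond donor and a hydrogen-bond acceptor that bromo lacks. Hydrogen in place of methyl on the oxygen gives a 1.1-fold lower number from compound 1 to compound 4 (0.02 log units; within the scatter) and also stays within the scatter. Bromo, methoxy and hydroxy therefore do not separate at this place on the aromatic ring, and the single earlier step now has two more beside it that read the same way.

As far as these compounds go, whether an amine, a carboxylic acid or a longer chain at this place would give a step beyond the scatter remains open. From the compounds shown here alone, it is also open whether hydroxy reads the same on the core of compound 3, and nothing at hand offers a cause for the three groups reading alike.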